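Chloro substitution on the shared core: growth inhibition notes

The compounds below may be only part of what the source reports. "The series", "measured", "known", "first", "only" and "open" are said of these compounds alone.

Compound 1 `COC(=O)[C@@]1(C)CC[C@@H]2C3=C1CC[C@@H](C)[C@]3(C)C[C@@H]1c3ccccc3N[C@H]21` is the parent of the pair. Going by the values given here, in a functional assay on A549 cells (Homo sapiens) for inhibition, read by sulforhodamine B assay, with a stated time of 48 h (on this read-out higher numbers stand for weaker inhibition of growth and lower numbers for stronger inhibition of growth), compound 1 gives 39000 nM, the highest of the two numbers so far. Compound 2 `COC(=O)[C@@]1(C)CC[C@@H]2C3=C1CC[C@@H](C)[C@]3(C)C[C@@H]1c3cc(OC)ccc3N[C@H]21` gives 22000 nM in this assay, and the step of a 1.8-fold lower number from compound 1 to compound 2 (0.25 log units; within the scatter) stays within the scatter. Compound 3 `COC(=O)[C@@]1(C)CC[C@@H]2C3=C1CC[C@@H](C)[C@]3(C)C[C@@H]1c3cccc(Cl)c3N[C@H]21` carries chloro in place of hydrogen on an aromatic carbon, ortho to a fused ring. Among the compounds with values here, no measured step covers a chloro group, and the only aromatic change measured did not move the number. Compound 3 is therefore expected to stay near compound 1, with a step of a 1.3-fold lower number from compound 1 to compound 3 (0.11 log units; within the scatter) inside the scatter. The estimate for compound 3 is 30000 nM, ranging from 10000 nM to 90000 nM.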

Compound 3, concentration for 50% growth inhibition: 54000 nM
Estimate against measurement, compound 3: 1.8-fold (0.26 log units) below, and the stated range covers the measured number.
By their numbers in this assay, from the lowest: compounds 2, 1 and 3 (each within the scatter of the next, the first and the last beyond it).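

In this assay, chloro in place of hydrogen on an aromatic carbon, ortho to a fused ring, gives a 1.4-fold higher number from compound 1 to compound 3 (0.14 log units; within the scatter) and so leaves the number within the scatter of the parent. This position therefore accepts a single chlorine on the shared core with no readable effect on growth inhibition.

Open, on these data alone, is whether an amine or a carboxylic acid at this carbon would give a step beyond the scatter. Also open, as far as these compounds go, is whether chloro on the other aromatic carbons would read the same. No supporting data bear on this result.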